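The source may report more compounds than this note shows. Statements on the series, on what has been measured and on what is new or still open speak of the compounds shown alone.

Measured compounds in this study:

compound 1, `COc1nc(Cl)nc(Nc2ccc(Cl)c(OCC=C(C)C)c2)n1`: 26000 nM
compound 2, `COc1nc(Nc2ccc(Cl)c(OCC=C(C)C)c2)nc(OC)n1`: 20000 nM
compound 3, `CC(C)=CCOc1cc(Nc2ncnc(Cl)n2)ccc1C#N`: > 100000 nM

All three were tested in an ADME assay on MT2 cells (Homo sapiens) for cytotoxicity; on this read-out lower numbers stand for higher toxicity in this test and higher numbers for lower toxicity in this test. Compound 1 and compound 2 share one core and differ in a single place. That difference is methoxy in place of chloro on an aromatic carbon. The step it made was a 1.3-fold lower number from compound 1 to compound 2 (0.11 log units; within the scatter), so the two values cannot be told apart in this assay.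

Compound 3 carries a different core, and how its core differs from that of compound 1 is not broken down here. For compound 3 this assay gave only a limit, (the limit of > 100000 nM in this assay, at which 1 of the 3 values shown sits); no number was reached.

Compound 4, `COc1ncnc(Nc2ccc(C#N)c(OCC=C(C)C)c2)n1`, has not yet been measured in this assay. It comes from compound 3 by methoxy in place of chloro on an aromatic carbon. The surroundings are not word for word the same as in the earlier pair: there the place was also meta to a methoxy group, here it is not, so this is the same kind of change rather than the same change.

Because the earlier pair showed a 1.3-fold lower number from compound 1 to compound 2 (0.11 log units; within the scatter), a step of similar size is expected here, a step that the limit leaves unreadable from compound 3 to compound 4. Since compound 3 sits at a limit, compound 4 is also expected to give a limit rather than a number in most repeats. The estimate for compound 4 in this assay is 120000 nM, with a range from 50000 nM to 300000 nM.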

Compound 4, half-maximal cytotoxic concentration: 42000 nM
The estimate for compound 4 lay 2.9-fold (0.46 log units) above the measured number; measured number below the stated range.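

In this assay, methoxy in place of chloro on an aromatic carbon gave an at least 2.3-fold lower number from compound 3 to compound 4 (0.37 log units; beyond the scatter), so on this core the change goes with a step beyond the usual scatter, and the true step may be larger than the one printed. From the compounds shown here alone, compound 3 gives only a limit, > 100000 nM, and not a number, so the full size of this step stays unknown. Two pairs are too few to make a rule, and this result shows neither that the change carries over from one core to the other with the same size nor that its size depends on the core: the same change on two cores in this assay, a 1.3-fold lower number (0.11 log units; within the scatter) from compound 1 to compound 2 and an at least 2.3-fold lower number (0.37 log units; beyond the scatter) from compound 3 to compound 4; the limit leaves it open whether they differ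

The compounds shown carry only chloro or methoxy at this place on the ring, so it remains open how an amine or a longer chain such as ethoxy would fare there in this assay. Going by these compounds, it also remains open whether the same change would give a step of similar size on further cores, where both partners of a pair reach a number rather than a limit.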